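A few compounds are considered here, and "the series" means these few. Any claim that something is new, unique, unknown or untested is made for them only; others in the source may bear on it.

The measured compounds: compound 1 `COc1ncc(-c2ccc3ncnc(Nc4ccc(OCCO)c(F)c4)c3c2)cc1NS(=O)(=O)c1ccc(F)cc1F`, 9160 nM in a functional assay on HCT-116 cells (Homo sapiens) for antiproliferative activity, read by sulforhodamine B assay, with a stated time of 72 h; on this read-out higher numbers stand for weaker inhibition and lower numbers for stronger inhibition; compound 2 `COC(=O)Cn1cc(Nc2ncnc3ccc(-c4cnc(OC)c(NS(=O)(=O)c5ccc(F)cc5F)c4)cc23)cn1`, 1260 nM; compound 3 `COc1ncc(-c2ccc3ncnc(Nc4ccc(OCCO)nc4)c3c2)cc1NS(C)(=O)=O`, 5360 nM.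

Of these three, compound 1 gives the highest number; compound 3 lies within the scatter of it, while compound 2 lies beyond it. Compound 4 `COc1ncc(-c2ccc3ncnc(Nc4cnn(CCCO)c4)c3c2)cc1NS(=O)(=O)c1ccc(F)cc1F` differs from compound 1 by 1-(3-hydroxypropyl)-1H-pyrazol-4-yl in place of 3-fluoro-4-(2-hydroxyethoxy)phenyl on a nitrogen on an aromatic ring. Going by the values given here, the one measured step that bears on this exchange is the related one in which the same phenyl group gives way to a substituted pyrazolyl group, a 7.3-fold lower number from compound 1 to compound 2 (0.86 log units; beyond the scatter). Compound 4 keeps the pyrazole but carries a 3-hydroxypropyl chain rather than the (methoxycarbonyl)methyl chain, so a step toward a lower number, of broadly similar size, is expected in this assay. Compound 4 is therefore estimated at 2000 nM, within 800 nM to 5000 nM, an expected step of a 4.6-fold lower number from compound 1 to compound 4 (0.66 log units; beyond the scatter).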

Compound 4, half-maximal inhibitory concentration: 480 nM
Estimate against measurement, compound 4: 4.2-fold (0.62 log units) above; measured number below the stated range.
By their numbers in this assay, from the lowest: compound 4; then compound 2; then compounds 3 and 1 (each within the scatter of the next).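

On the nitrogen on an aromatic ring, exchanging the phenyl group for 1-(3-hydroxypropyl)-1H-pyrazol-4-yl gives a large step in this assay (a 19-fold lower number from compound 1 to compound 4 (1.28 log units; beyond the scatter)), so a second pyrazolyl compound now moves the same way as compound 2. The chain on the pyrazole also counts: 2-hydroxyethyl in place of methoxycarbonyl gives a further step (a 2.6-fold lower number from compound 2 to compound 4 (0.42 log units; beyond the scatter)). The pyrazole is thus not a fixed contribution, since the number shifts with what its chain carries. Nothing available explains either step. Going by these compounds, whether a terminal amine, a carboxylic acid or a longer chain would go lower remains open.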